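Para-Nitro in Place of Para-Methyl on the Benzyloxy Arm

The source may report more compounds than this note shows. Statements on the series, on what has been measured and on what is new or still open speak of the compounds shown alone.

Within the data shown here, in an assay for inhibition of Amine oxidase [flavin-containing] B (Rattus norvegicus) (on this read-out higher numbers stand for weaker inhibition and lower numbers for stronger inhibition), compound 1 `Cc1cccc(COc2ccc(C3=NN(CCC#N)C(=O)CO3)cc2)c1` gives 31 nM, and compound 2 `Cc1ccc(COc2ccc(C3=NN(CCC#N)C(=O)CO3)cc2)cc1` gives 320 nM, the higher of the two numbers; the only measured step, a 10-fold higher number from compound 1 to compound 2 (1.01 log units; beyond the scatter), moved the methyl but kept it. Compound 3 `N#CCCN1N=C(c2ccc(OCc3ccc([N+](=O)[O-])cc3)cc2)OCC1=O` brings a different change: nitro in place of methyl on an aromatic carbon. Among the measured compounds shown here, no measured step swaps one group for another at this position, so nothing here points in a direction, and for compound 3 the expected step in this assay is a 1.3-fold lower number from compound 2 to compound 3 (0.11 log units; within the scatter), within the scatter. Compound 3 is therefore estimated at 250 nM, between 50 nM and 1500 nM.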

Compound 3, half-maximal inhibitory concentration: 300 nM
For compound 3 the middle estimate is 1.2-fold (0.08 log units) below the measured one; measured number inside the range.
By their numbers in this assay, from the lowest: compound 1; then compounds 3 and 2 (each within the scatter of the next).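

In this assay, nitro and methyl at this place cannot be told apart: the swap gives only a 1.1-fold lower number from compound 2 to compound 3 (0.03 log units; within the scatter). The 4-nitrophenyl arm also leaves the gap to the 3-methylphenyl arm in place, with a 9.7-fold higher number from compound 1 to compound 3 (0.99 log units; beyond the scatter), much as the 4-methylphenyl arm did. Nothing measured here offers a reason for this match. Going by these compounds, whether an amine or a carboxylic acid at this place would read the same stays open. So does what nitro would give on the ring carbon where compound 1 carries its methyl.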